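Carbamate ester variation and stereochemistry at the rat receptor

The compounds below may be only part of what the source reports. "The series", "measured", "known", "first", "only" and "open" are said of these compounds alone.

Measured so far:
compound 1 `CC(C)(C)OC(=O)N1CCC(O[C@H]2CC[C@H](Oc3cnc(S(C)(=O)=O)cn3)CC2)CC1` — 110%
compound 2 `CC1(OC(=O)N2CCC(O[C@H]3CC[C@H](Oc4cnc(S(C)(=O)=O)cn4)CC3)CC2)CC1` — 123%
compound 3 `C[C@H](CF)OC(=O)N1CCC(O[C@H]2CC[C@H](Oc3cnc(S(C)(=O)=O)cn3)CC2)CC1` — 115%

All three share one core and differ only in the group on the oxygen next to the carbonyl. In a functional assay on isolated protein for agonist activity at Glucose-dependent insulinotropic receptor (Rattus norvegicus), read by HTRF and cAMP accumulation (on this read-out higher numbers stand for larger maximal responses and lower numbers for smaller maximal responses), compound 1 gives 110% and compound 2 gives 123%; the step of a number 13 percentage points higher from compound 1 to compound 2 (beyond the scatter) is the only one in the set beyond the scatter. Compound 3 gives 115% and sits second of the three numbers, within the scatter of both neighbours: the step of a number 5 percentage points higher from compound 1 to compound 3 (within the scatter) and the step of a number 8 percentage points lower from compound 2 to compound 3 (within the scatter) are both small.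

Compound 4 `C[C@@H](CF)OC(=O)N1CCC(O[C@H]2CC[C@H](Oc3cnc(S(C)(=O)=O)cn3)CC2)CC1` is the next candidate. The change is the two compounds have the same atoms and bonds and differ only in configuration as drawn: 2 of 3 stereo elements differ; a stereocentre at a saturated chain carbon is drawn R in compound 3 and S in compound 4; a stereocentre at a saturated ring carbon is drawn R in compound 3 and S in compound 4. Going by the values given here, no measured step concerns a change of configuration; the steps of a number 5 percentage points higher from compound 1 to compound 3 (within the scatter) and a number 8 percentage points lower from compound 2 to compound 3 (within the scatter) concern the identity of the ester group only, and the ring stereocentres have been the same in all three measured compounds. Nothing therefore points to a shift in either direction, and the expected step of a number 3 percentage points lower from compound 3 to compound 4 (within the scatter) is estimated to lie within the scatter. For compound 4 in this assay the expected value is 112%, with a range of 95% to 128%.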

Compound 4, largest response reached (Emax), in percent of the reference or control that the assay uses: 123%
Compound 4: middle estimate off by 11 percentage points, on the low side, within the range that was stated.
By their numbers in this assay, from the lowest: compounds 1, 3, 2 and 4 (each within the scatter of the next, the first and the last beyond it).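

Going by these compounds alone, this is the first pair that tests configuration, and in this assay it gives no separation beyond the scatter (a number 8 percentage points higher from compound 3 to compound 4 (within the scatter)), so the drawn configurations at the saturated chain carbon and the saturated ring carbon have no resolved effect on the maximal response here. Compound 4 also reads level with the 1-methylcyclopropyl ester (no change at the digits printed from compound 2 to compound 4 (within the scatter)) and becomes the second compound to clear the scatter against tert-butyl (a number 13 percentage points higher from compound 1 to compound 4 (beyond the scatter)), which compound 3 does not do (a number 5 percentage points higher from compound 1 to compound 3 (within the scatter)), although that contrast is weak with compounds 3 and 4 themselves within the scatter of each other. The reading of this pair is confined to stereochemistry, with no change of group involved: the fact that compounds 3 and 4 differ only in the configuration as drawn.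

Which of the two differing stereo elements contributes to the step stays open, as both change together in this pair. Also open, from the compounds shown here alone, is whether the level shared by compounds 2 and 4 holds for other groups on this oxygen, such as a 2,2-difluoroethyl group or a longer chain, or is exceeded by any of them.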